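A few compounds are considered here, and "the series" means these few. Any claim that something is new, unique, unknown or untested is made for them only; others in the source may bear on it.

Measured compounds:
- Compound 1 `CCCN(CC[C@H](N)C(=O)O)C[C@H]1O[C@@H](n2cnc3c(N)ncnc32)[C@H](O)[C@@H]1O`: no result reported in an assay for inhibition of tRNA (cytosine(38)-C(5))-methyltransferase (Homo sapiens), with a stated time of 5 min, tested at 100 uM; a higher number here means more inhibition at the concentration tested (going by the name of the read-out), a lower number less inhibition
- Compound 2 `CC(C)N(CC[C@H](N)C(=O)O)C[C@H]1O[C@@H](n2cnc3c(N)ncnc32)[C@H](O)[C@@H]1O`: 44%

Going by the values given here, compound 2 gives the only number here; in this assay compound 2 reaches 44%, a middling level of inhibition. Compound 3 `Nc1ncnc2c1ncn2[C@@H]1O[C@H](CN(CC[C@H](N)C(=O)O)CC2CC2)[C@@H](O)[C@H]1O` differs from compound 2 only by cyclopropylmethyl in place of isopropyl on an amine nitrogen. Among the compounds with values here, no measured pair shows what such a swap does in this assay, so the step is expected to stay within the usual scatter, in no clear direction: a number 2 percentage points lower from compound 2 to compound 3 (within the scatter) is the estimated change. Compound 3 is therefore expected to give about 42% in this assay, plausibly anywhere from 15% to 70%.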

Compound 3, a percentage reported as inhibition, at one concentration (the size of the read-out at that concentration, not a potency): 27.5%
Compound 3: the middle estimate sits 14.5 percentage points above what was measured; low and high end bracket the measured number.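

This nitrogen is sensitive to the choice of group: in this assay, cyclopropylmethyl in place of isopropyl gives a number 16.5 percentage points lower from compound 2 to compound 3 (beyond the scatter). So even a swap between two small carbon-only groups with no hydrogen-bond donors or acceptors can shift inhibition at this position. No measurement here explains the drop. With a single pair, the ring's effect cannot be separated from that of the larger group. As far as these compounds go, it remains open how a methyl, an open butyl chain or a group carrying an amine would fare on this nitrogen.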